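Compound 4: a carbonyloxy group in place of methanesulfonamido

A few compounds are considered here, and "the series" means these few. Any claim that something is new, unique, unknown or untested is made for them only; others in the source may bear on it.

Measured so far in an ADME assay on cells (Hepatocyte, Mus musculus) for metabolic stability; a lower number here means that the compound disappears faster, a higher number that the compound lasts longer:
compound 1 `CS(=O)(=O)NC1CCC(CN2CCN(c3cc(=O)c4cc(C(F)(F)F)cc([N+](=O)[O-])c4s3)CC2)CC1` — > 1.55 h
compound 2 `O=C(NC1CCC(CN2CCN(c3cc(=O)c4cc(C(F)(F)F)cc([N+](=O)[O-])c4s3)CC2)CC1)c1ccccc1` — > 1.55 h
compound 3 `Cc1ccc(C(=O)OC2CCC(CN3CCN(c4cc(=O)c5cc(C(F)(F)F)cc([N+](=O)[O-])c5s4)CC3)CC2)cc1` — 0.202 h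

In this assay compound 1 gives > 1.55 h, which is a limit of the assay and not a number. Compound 2 gives > 1.55 h, likewise a limit. Compound 3 gives 0.202 h. Compound 1 therefore stands at the limit of > 1.55 h in this assay, at which 2 of the 3 values shown sit, and its place is readable only against compound 3. Compound 4 `O=C(OC1CCC(CN2CCN(c3cc(=O)c4cc(C(F)(F)F)cc([N+](=O)[O-])c4s3)CC2)CC1)C1CCCCC1` differs from compound 1 by (cyclohexylcarbonyl)oxy in place of methanesulfonamido on a saturated ring carbon. Among the compounds with values here, the steps that bear on this change are an at least 7.6-fold lower number from compound 1 to compound 3 (0.88 log units; beyond the scatter) and an at least 7.6-fold lower number from compound 2 to compound 3 (0.88 log units; beyond the scatter), both a clear fall, while a step that the two limits leave unreadable from compound 1 to compound 2 cannot be read. A fall of like size is expected here, namely an at least 6.2-fold lower number from compound 1 to compound 4 (0.79 log units; beyond the scatter). Compound 4 is thus estimated at 0.25 h, with a range of 0.08 h to 0.8 h.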

Compound 4, half-life: 0.0783 h
Beside the measured number, compound 4's estimate is 3.2-fold (0.50 log units) above it, outside the stated range (below it).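

In this assay, a second carbonyloxy group on the saturated ring carbon gives a fall, with an at least 19-fold lower number from compound 1 to compound 4 (1.29 log units; beyond the scatter) and an at least 19-fold lower number from compound 2 to compound 4 (1.29 log units; beyond the scatter). New is that the group on the carbonyl carbon also counts within the carbonyloxy pair, with cyclohexyl in place of 4-methylphenyl giving a 2.6-fold lower number from compound 3 to compound 4 (0.41 log units; beyond the scatter). Compound 1 and compound 2 each stand at a limit and not at a number: the limit of > 1.55 h in this assay, at which 2 of the 4 values shown sit.

The step between compound 1 and compound 2 cannot be read. As far as these compounds go, whether a carbamate or a simple ether on the same ring carbon follows compound 3 and compound 4 or compound 1 and compound 2 remains open.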